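Three ureas on one core, and a fourth to come

A few compounds are considered here, and "the series" means these few. Any claim that something is new, unique, unknown or untested is made for them only; others in the source may bear on it.

Compound 1 `O=C(Nc1cccc(-n2cc(-c3ccncc3)c(-c3cc(O)cc(Cl)c3)n2)c1)Nc1ccc(Cl)c(C(F)(F)F)c1` gives 95% in a functional assay on SF-268 cells (Homo sapiens) for inhibition, read by sulforhodamine B assay, with a stated time of 48 h, tested at 0.01 uM; on this read-out higher numbers stand for a weaker effect at the one concentration tested and lower numbers for a stronger effect.
Compound 2 `O=C(Nc1cccc(-n2cc(-c3ccncc3)c(-c3cc(O)cc(Cl)c3)n2)c1)Nc1ccc(Cl)c(Cl)c1` gives 94% in this assay.
Compound 3 `COc1cc(Cl)cc(-c2nn(-c3cccc(NC(=O)Nc4cc(C(F)(F)F)cc(C(F)(F)F)c4)c3)cc2-c2ccncc2)c1` gives 97% in this assay.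

Of the three, compound 3 carries the highest number, yet its gaps to compound 1 and to compound 2 both lie within the scatter, so the three stand level. Among the measured compounds shown here, the one measured step, a number 1 percentage points lower from compound 1 to compound 2 (within the scatter), shows that swapping one group for another on that terminal ring left the read-out untouched.

Compound 4 `COc1cc(Cl)cc(-c2nn(-c3cccc(NC(=O)Nc4cccc(C(F)(F)F)c4)c3)cc2-c2ccncc2)c1` is compound 3 with the change (hydrogen in place of trifluoromethyl on an aromatic carbon). For the measured compounds named here, the step from compound 1 to compound 2 is the only one that bears on it, and it was flat; no measured pair shows what the loss of a trifluoromethyl group does here. On that basis no step beyond the scatter is expected in this assay for compound 4, in either direction.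

The estimated step for compound 4 is therefore a number 2 percentage points lower from compound 3 to compound 4 (within the scatter). Compound 4 is expected to give 95%, within a range from 86% to 100%.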

Compound 4, a percentage reported as activity, at one concentration (the size of the read-out at that concentration, not a potency): 97%
Compound 4: middle estimate off by 2 percentage points, on the low side; the range from low to high includes it.
By their numbers in this assay, from the lowest: compounds 2, 1, 3 and 4 (each within the scatter of the next).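

In this assay, replacing a trifluoromethyl group with hydrogen gave no change at the digits printed from compound 3 to compound 4 (within the scatter), so on this scaffold the ring position meta to a trifluoromethyl group lost four heavy atoms without any shift beyond the scatter. The earlier step had only exchanged one substituent for another in a different pair, whereas this one removes the substituent outright and still leaves the read-out flat at the single concentration tested. No available evidence bears on why this change left the read-out flat.

The compounds shown leave open whether an amine or a carboxylic acid at this position would shift the read-out beyond the scatter. Among the compounds shown here, they also contain no pair that differs only in hydroxyl versus methoxy on the chlorinated ring, so that exchange remains unresolved.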